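From 4-ethylphenyl to 2,3-dimethylphenyl on a sulfonamide

This account rests on a few compounds, and the source may have more. Where it says the series, first, only, none or still open, it means among the compounds named here.

compound 1 `CCc1ccc(NS(=O)(=O)c2ccc(N3CCNC3=O)cc2)cc1` gives 810 nM
compound 2 `CC(C)(C)c1ccc(NS(=O)(=O)c2ccc(N3CCNC3=O)cc2)cc1` gives > 1000 nM
compound 3 `O=C1NCCN1c1ccc(S(=O)(=O)Nc2ccc(OC(F)F)cc2)cc1` gives 760 nM

These results come from a functional assay on MCF7 cells (Homo sapiens) for antiproliferative activity, read by sulforhodamine B assay, with a stated time of 48 h (on this read-out higher numbers stand for weaker inhibition and lower numbers for stronger inhibition), and all three compounds share one core. The entry for compound 2 is a limit of the assay and not a number. Compound 1 stands at 810 nM and its nearest neighbour shows a 1.1-fold lower number from compound 1 to compound 3 (0.03 log units; within the scatter) so these two cannot be ranked.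

In compound 4 (`Cc1cccc(NS(=O)(=O)c2ccc(N3CCNC3=O)cc2)c1C`) the core of compound 1 stays, and the change reads 2,3-dimethylphenyl in place of 4-ethylphenyl on a sulfonamide nitrogen with the same atoms joined differently. In words, 2,3-dimethylphenyl replaces 4-ethylphenyl on a sulfonamide nitrogen.

The measured steps all swap one group on an aromatic carbon. Going by these compounds, they are an at least 1.2-fold higher number from compound 1 to compound 2 (0.09 log units; that floor lies within the scatter) and also an at least 1.3-fold lower number from compound 2 to compound 3 (0.11 log units; that floor lies within the scatter) and both of these are only floors, so their true size stays open. Within the data shown here, none of the measured compounds carries 2,3-dimethylphenyl, which makes them a loose guide. Even so, the small step of a 1.1-fold lower number from compound 1 to compound 3 (0.03 log units; within the scatter) gives no reason to expect a large move, so no step beyond the scatter is expected in this assay and no direction can be called. The estimate therefore means a 1.0-fold higher number from compound 1 to compound 4 (0.02 log units; within the scatter) as the expected step.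

Compound 4 is expected at 850 nM with an estimated range from 450 nM to 1600 nM as its likely span.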

Compound 4, half-maximal inhibitory concentration: 230 nM
Beside the measured number, compound 4's estimate is 3.7-fold (0.57 log units) above it; the whole stated range lies above it.
By their numbers in this assay, from the lowest: compound 4; then compounds 3 and 1 (each within the scatter of the next). At a limit, above all of these: compound 2.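

In this assay, a 3.5-fold lower number from compound 1 to compound 4 (0.55 log units; beyond the scatter) is the first step among these compounds that is shown to exceed the scatter, as the earlier steps were either too small to rank the compounds or only floors. It shows that the response at this position on the sulfonamide nitrogen can change measurably even when the atoms stay the same and are only joined differently, since 2,3-dimethylphenyl and 4-ethylphenyl match in every count computed for them. Nothing in the information available explains why this rearrangement gives the lower number.

Because 2,3-dimethylphenyl differs from 4-ethylphenyl in the whole pattern of its substituents, these compounds cannot show whether a single methyl group on the ring would be enough, or whether both methyl groups are needed. Going by these compounds, it also remains open how an amine, a carboxylic acid or a longer chain on this ring would read, and what any change to the shared core would do.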